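The source may hold more compounds than are shown below. What is called first, only, known or untested is meant among the compounds shown, and "the series" means these compounds.

Working notes on the series. Compound 1 `CNc1ncc2c(-c3ccc(N4CCNCC4)nc3)nn(Cc3cn(Cc4ccccc4)nn3)c2n1` bears hydrogen on the amine nitrogen in the ring; in an assay for inhibition of tyrosine-protein kinase Mer (Homo sapiens), read by 33P incorporation, in the presence of a further agent that is not named here (a higher number here means a weaker inhibitor, a lower number a stronger inhibitor), compound 1 gives 2300 nM. Compound 2 `CNc1ncc2c(-c3ccc(N4CCN(C)CC4)nc3)nn(Cc3cn(Cc4ccccc4)nn3)c2n1` bears methyl on that nitrogen, and in this assay compound 2 gives 2000 nM; the step of a 1.2-fold lower number from compound 1 to compound 2 (0.06 log units; within the scatter). Compound 3 `CCN1CCN(c2ccc(-c3nn(Cc4cn(Cc5ccccc5)nn4)c4nc(NC)ncc34)cn2)CC1` bears ethyl on the same nitrogen. On these data alone, for compound 3 in this assay only a limit is recorded, > 10000 nM, so compound 3 sits at the limit of > 10000 nM in this assay, at which 1 of the 3 values shown sits, and its true number is unknown. Accordingly the steps of an at least 4.3-fold higher number from compound 1 to compound 3 (0.63 log units; beyond the scatter) and an at least 5.0-fold higher number from compound 2 to compound 3 (0.69 log units; beyond the scatter) are bounds, not measured sizes. Compound 4 `CNc1ncc2c(-c3ccc(N4CCN(C(=O)C(C)(C)C)CC4)nc3)nn(Cc3cn(Cc4ccccc4)nn3)c2n1` is the next member: (tert-butyl)carbonyl in place of ethyl on an amine nitrogen in a ring. Among the measured compounds shown here, no measured step covers an acyl group on this nitrogen, so neither direction is supported by data; the measured steps show only that ethyl in place of hydrogen or methyl lifts the number past the limit. Starting from a limit, the expected step is a number no higher from compound 3 to compound 4 (the limit leaves the size open), with wide uncertainty. Compound 4 is therefore estimated at 10000 nM, with a range from 3000 nM to 30000 nM.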

Compound 4, half-maximal inhibitory concentration: 5400 nM
For compound 4 the middle estimate is 1.9-fold (0.27 log units) above the measured one; low and high end bracket the measured number.
By their numbers in this assay, from the lowest: compounds 2 and 1 (each within the scatter of the next); then compound 4. At a limit, above all of these: compound 3.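

In this assay, (tert-butyl)carbonyl on the amine nitrogen in the ring still gives a measurable number, so a group larger than ethyl at this position does not necessarily carry the number past the limit, although an at least 1.8-fold lower number from compound 3 to compound 4 (0.26 log units; that floor lies within the scatter) is only a bound. Against the smaller substituents the acyl group does not match the earlier numbers, with a 2.7-fold higher number from compound 2 to compound 4 (0.43 log units; beyond the scatter) and a 2.3-fold higher number from compound 1 to compound 4 (0.37 log units; beyond the scatter) as the measured steps. The order of substituents by size therefore does not follow the numbers, since compound 4, with the largest group, lies on the measurable side of compound 3.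

On these data alone, whether acetyl, a bare tert-butyl without the carbonyl or a longer chain on this nitrogen would fall with compound 3 or with compound 4 stays open. How far compound 3 truly lies from compound 4 also stays open, as compound 3 is recorded only as a limit: the limit of > 10000 nM in this assay, at which 1 of the 4 values shown sits.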